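A few compounds are considered here, and "the series" means these few. Any claim that something is new, unique, unknown or untested is made for them only; others in the source may bear on it.

Of the compounds shown here, three built on one shared core have been measured. Compound 1 `CS(=O)(=O)N1CC(CCl)c2ccc(O)cc21` gives 4.24 ug/mL in a functional assay on KB cells (Homo sapiens), read by crystal violet staining; a lower number here means a stronger inhibitor, a higher number a weaker inhibitor. Compound 2 `COC(=O)c1cc2c(cc1OCc1ccccc1)N(S(C)(=O)=O)CC2CCl` gives 7.14 ug/mL in this assay. Compound 3 `CS(=O)(=O)N1CC(CCl)c2cc(C=O)c(O)cc21` gives 4.83 ug/mL in this assay, the second highest of the three numbers, with compound 1 nearest and compound 2 furthest, both within the scatter. Among the compounds with values here, the only step between measured compounds that differ in one place is a 1.1-fold higher number from compound 1 to compound 3 (0.06 log units; within the scatter), a formyl in place of hydrogen on an aromatic carbon. Compound 4 `COC(=O)c1cc2c(cc1O)N(S(C)(=O)=O)CC2CCl` differs from compound 3 by methoxy in place of hydrogen on a carbonyl carbon. Within the data shown here, no measured step carries this exact change, and the one known step is small, so compound 4 is expected to show a 1.1-fold higher number from compound 3 to compound 4 (0.06 log units; within the scatter). Compound 4 is therefore estimated at 5.5 ug/mL, ranging from 2.5 ug/mL to 12 ug/mL.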

Compound 4, half-maximal inhibitory concentration: 8.38 ug/mL
Compound 4: the middle estimate sits 1.5-fold (0.18 log units) below what was measured; measured number inside the range.
By their numbers in this assay, from the lowest: compounds 1, 3, 2 and 4 (each within the scatter of the next).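

In this assay, methoxy in place of hydrogen on the carbonyl carbon, which turns formyl into methoxycarbonyl, gives a 1.7-fold higher number from compound 3 to compound 4 (0.24 log units; within the scatter) and so stays inside the usual noise. Taking benzyl off the oxygen gives a 1.2-fold higher number from compound 2 to compound 4 (0.07 log units; within the scatter), and methoxycarbonyl in place of hydrogen on the aromatic carbon gives a 2.0-fold higher number from compound 1 to compound 4 (0.30 log units; within the scatter), so neither step separates from the scatter either. No outside data bear on these results.

As far as these compounds go, it remains open whether a carboxylic acid or an amine on that aromatic carbon would shift the number beyond the scatter.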